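A Fluorine Atom Added to the Phenyl of Compound 2

The source may hold more compounds than are shown below. What is called first, only, known or untested is meant among the compounds shown, and "the series" means these compounds.

Compound 2 `O=C(Nc1cc(-c2ccccn2)n[nH]1)N1CCC(c2ccccc2)CC1` stands highest of the two numbers measured in an ADME assay on liver (Mesocricetus auratus) for metabolic stability, using microsomes (on this read-out lower numbers stand for slow clearance and higher numbers for fast clearance), where compound 2 gives 216 mL.min-1.g-1. Its nearest neighbour is compound 1 `O=C(Nc1cc(-c2ccccn2)n[nH]1)N1CCC(Oc2ccccc2)CC1`, which in this assay gives 98.5 mL.min-1.g-1. Among the compounds with values here, the only measured step, a 2.2-fold higher number from compound 1 to compound 2 (0.34 log units; beyond the scatter), exchanges phenyl for phenoxy on a saturated ring carbon. Compound 3 `O=C(Nc1cc(-c2ccccn2)n[nH]1)N1CCC(c2cccc(F)c2)CC1` differs from compound 2 by fluoro in place of hydrogen on an aromatic carbon. Within the data shown here, no measured step involves this kind of change; the one recorded step concerns a different part of the molecule and offers no direct guide. Without a bearing step, the expected step in this assay is a 1.1-fold lower number from compound 2 to compound 3 (0.03 log units; within the scatter), which is not expected to exceed the scatter. Compound 3 is therefore estimated at 200 mL.min-1.g-1, within a range from 100 mL.min-1.g-1 to 400 mL.min-1.g-1.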

Compound 3, intrinsic clearance in microsomes: 207 mL.min-1.g-1
Compound 3: the middle estimate sits 1.0-fold (0.01 log units) below what was measured, within the range that was stated.
By their numbers in this assay, from the lowest: compound 1; then compounds 3 and 2 (each within the scatter of the next).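

In this assay, fluoro in place of hydrogen on an aromatic carbon, meta to a large group, gives a 1.0-fold lower number from compound 2 to compound 3 (0.02 log units; within the scatter), so compound 2 and compound 3 cannot be told apart on this read-out. The separation from the phenoxy compound also holds with this substituent, with a 2.1-fold higher number from compound 1 to compound 3 (0.32 log units; beyond the scatter), so 3-fluorophenyl stands apart from phenoxy just as unsubstituted phenyl does. Nothing available explains why this single fluoro atom leaves the clearance within the scatter.

Still open, as far as these compounds go, is whether fluoro elsewhere on this ring, or a different group at this same place, such as trifluoromethyl, a nitrile or an amine, would take the number beyond the scatter. Also open, from the compounds shown here alone, is whether fluoro on the phenoxy ring of compound 1 would behave as it does here.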